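Oral exposure in rat: from a pyrazole to an amine

This account rests on a few compounds, and the source may have more. Where it says the series, first, only, none or still open, it means among the compounds named here.

Compound 1 `CCN1CCN(c2ccc3oc([C@]4(CN5Cc6ccc(OC)c(F)c6C5=O)NC(=O)N(COC(=O)C(C)(C)C)C4=O)cc3n2)CC1`: 12700 ng.h/mL
Compound 2 `COc1ccc2c(c1F)C(=O)N(C[C@@]1(c3cc4nc(N5CCNC(=O)C5)ccc4o3)NC(=O)N(COC(=O)C(C)(C)C)C1=O)C2`: 374 ng.h/mL
Compound 3 `COc1ccc2c(c1F)C(=O)N(C[C@@]1(c3cc4nc(-c5cn[nH]c5)ccc4o3)NC(=O)N(COC(=O)C(C)(C)C)C1=O)C2`: 177 ng.h/mL

Three compounds sharing one core have been run in an ADME assay on the whole organism for pharmacokinetics, with Rattus norvegicus as the target, read by LC-MS, at a dose of 10 mg/kg by the oral route; on this read-out lower numbers stand for lower exposure and higher numbers for higher exposure at the dose given. Compound 1 gives the highest exposure of the set. Exposure drops sharply in the step of a 34-fold lower number from compound 1 to compound 2 (1.53 log units; beyond the scatter) and again in the step of a 72-fold lower number from compound 1 to compound 3 (1.86 log units; beyond the scatter). Between the two lower compounds the gap is smaller: the step of a 2.1-fold lower number from compound 2 to compound 3 (0.32 log units; beyond the scatter) leaves compound 3 with the lowest number among the three measured, with compound 2 nearest and compound 1 furthest away.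

Compound 4 `COc1ccc2c(c1F)C(=O)N(C[C@@]1(c3cc4nc(N)ccc4o3)NC(=O)N(COC(=O)C(C)(C)C)C1=O)C2` has not yet been measured. It arises from compound 3 by a single change: amino in place of 1H-pyrazol-4-yl on an aromatic carbon. Among the compounds with values here, no measured step swaps in an amino group, so the two steps that reach compound 3 are the closest guide: both replacements of the 4-ethylpiperazin-1-yl group moved exposure a long way down, and the exchange between compound 2 and compound 3 moved it only modestly. On that basis compound 4 is expected to stay in the low region, with a step of a 1.4-fold higher number from compound 3 to compound 4 (0.15 log units; within the scatter) of modest size and uncertain direction. The expected exposure for compound 4 in this assay is 250 ng.h/mL, within a range from 80 ng.h/mL to 800 ng.h/mL.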

Compound 4, area under the concentration-time curve: 216 ng.h/mL
Compound 4: the middle estimate sits 1.2-fold (0.06 log units) above what was measured, and the stated range covers the measured number.
By their numbers in this assay, from the lowest: compounds 3, 4 and 2 (each within the scatter of the next, the first and the last beyond it); then compound 1.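

In this assay, amino has 1 heavy atom and no ring, whereas 1H-pyrazol-4-yl has 5 heavy atoms and a five-membered aromatic ring, yet putting amino on this aromatic carbon next to the ring nitrogen gives a 1.2-fold higher number from compound 3 to compound 4 (0.09 log units; within the scatter) and leaves the two compounds indistinguishable. The comparison with the 3-oxopiperazin-1-yl group also gives no separation, with a 1.7-fold lower number from compound 2 to compound 4 (0.24 log units; within the scatter), while the comparison with the 4-ethylpiperazin-1-yl group gives a 59-fold lower number from compound 1 to compound 4 (1.77 log units; beyond the scatter), so among these four compounds only compound 1 stands apart, and the group's size alone does not account for that. No measurement shown here bears on what lies behind these differences in exposure.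

The compounds shown leave open which part of the 4-ethylpiperazin-1-yl group sets compound 1 apart: the ethyl chain, the piperazine ring or the ring's second nitrogen. A piperazine without the ethyl chain, a morpholine or a dimethylamino group on the same carbon would help separate these parts, though any such result would apply only to this shared core.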